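Chain lengthening and aryl substituent swap in one cytotoxicity series

The source may report more compounds than this note shows. Statements on the series, on what has been measured and on what is new or still open speak of the compounds shown alone.

Measured so far:
compound 1, `CCc1cc2ccccc2nc1-c1cc(-c2ccc(F)cc2)no1` — a limit only, > 100000 nM
compound 2, `CCCc1cc2ccccc2nc1-c1cc(-c2ccc(F)cc2)no1` — 48400 nM
compound 3, `CCCc1cc2ccccc2nc1-c1cc(-c2ccc(C(F)(F)F)cc2)no1` — 36500 nM

In a functional assay on MDA-MB-231 cells (Homo sapiens) for inhibition, read by MTT assay, with a stated time of 24 h (on this read-out lower numbers stand for stronger inhibition and higher numbers for weaker inhibition), compound 1 reaches only a limit, > 100000 nM (the limit of > 100000 nM in this assay, at which 1 of the 3 values shown sits). Compound 2 gives 48400 nM, the step being an at least 2.0-fold lower number from compound 1 to compound 2 (0.31 log units; beyond the scatter), made by methyl in place of hydrogen on a saturated chain carbon, two bonds along the chain from an aromatic carbon. Compound 3 gives 36500 nM; the step of a 1.3-fold lower number from compound 2 to compound 3 (0.12 log units; within the scatter) is made by trifluoromethyl in place of fluoro on an aromatic carbon and sits within scatter of compound 2, so no order is drawn between them.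

Compound 4, `CCCCc1cc2ccccc2nc1-c1cc(-c2ccc(C(F)(F)F)cc2)no1`, awaits measurement. It differs from compound 3 by methyl in place of hydrogen on a saturated chain carbon, three bonds along the chain from an aromatic carbon. This is the same kind of change as from compound 1 to compound 2, but the place differs: two bonds along the chain there, three bonds along the chain here. How the core of compound 1 and that of compound 3 differ is not broken down here.

The expected step is a 1.5-fold lower number from compound 3 to compound 4 (0.16 log units; within the scatter), resting on an at least 2.0-fold lower number from compound 1 to compound 2 (0.31 log units; beyond the scatter), which started from a limit and so sets only a floor. Compound 4 is estimated at 25000 nM, between 9000 nM and 70000 nM.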

Compound 4, half-maximal inhibitory concentration: 10400 nM
The estimate for compound 4 lay 2.4-fold (0.38 log units) above the measured number, within the range that was stated.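

In this assay, methyl in place of hydrogen on a saturated chain carbon, three bonds along the chain from an aromatic carbon, gives a 3.5-fold lower number from compound 3 to compound 4 (0.55 log units; beyond the scatter). The same kind of change therefore lowers the number on both cores, though at different places along the chain, and the two steps compare as follows: the same change on two cores in this assay, an at least 2.0-fold lower number (0.31 log units; beyond the scatter) from compound 1 to compound 2 and a 3.5-fold lower number (0.55 log units; beyond the scatter) from compound 3 to compound 4; the limit leaves it open whether they differ
Compound 1 stands at a limit, so these compounds show the direction of the change on both cores but not whether its size carries over: the limit of > 100000 nM in this assay, at which 1 of the 4 values shown sits.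

Still open, as far as these compounds go, is whether a pentyl chain, or a chain carrying an amine, would lower the number further on the core of compound 4. Also open, from the compounds shown here alone, is whether the step from propyl to butyl holds with fluoro in place of trifluoromethyl on the aromatic carbon.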